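This account rests on a few compounds, and the source may have more. Where it says the series, first, only, none or still open, it means among the compounds named here.

Measured compounds:
- compound 1, `O=C(O)[C@H]1CCC[C@@H](c2ccc3ccccc3c2)O1`, 43.1%
- compound 2, `OC[C@H]1CCC[C@@H](c2ccc3ccccc3c2)O1`, 55.7%
- compound 3, `OC[C@H]1C[C@@H](Cl)C[C@@H](c2ccc3ccccc3c2)O1`, 46.6%

All three were tested in a functional assay on the whole organism (Abdomen, strain Swiss albino) for inhibition, with Mus musculus as the target, in the writhing test, with a stated time of 30 min, at a dose of 30 mg/kg by the oral route; a higher number here means more inhibition at the dose given (going by the name of the read-out), a lower number less inhibition. Compound 2 gives 55.7%, and two single changes were made to it. The first is carboxy in place of hydroxymethyl on a saturated ring carbon, which produced a number 12.6 percentage points lower from compound 2 to compound 1 (beyond the scatter). The second is chloro in place of hydrogen on a saturated ring carbon, which produced a number 9.1 percentage points lower from compound 2 to compound 3 (within the scatter). Compound 3 and compound 1 are not compared as a step here; their values sit within the usual scatter of each other, so nothing can be said about their order.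

Compound 4, `O=C(O)[C@H]1C[C@@H](Cl)C[C@@H](c2ccc3ccccc3c2)O1`, has not been measured. It differs from compound 3 by carboxy in place of hydroxymethyl on a saturated ring carbon. For the measured compounds named here, this is the same kind of change as the one from compound 2 to compound 1, but the place is not identical: in compound 3 the ring atom that carries the group is also two ring bonds from the ring atom that bears a chloro group, which has no counterpart in compound 2. The cores of compound 2 and compound 3 differ by chloro in place of hydrogen on a saturated ring carbon.

Going by the values given here, the change from hydroxymethyl to carboxy is seen once among the measured compounds, as a number 12.6 percentage points lower from compound 2 to compound 1 (beyond the scatter), and compound 3 is expected to show a similar step, a number 12.6 percentage points lower from compound 3 to compound 4 (beyond the scatter), because the only support is a number 12.6 percentage points lower from compound 2 to compound 1 (beyond the scatter). On that basis compound 4 is estimated to give 34% in this assay . Among the compounds with values here, the expected range for compound 4 runs from 22% to 46%, reflecting that the single precedent and the extra chloro group leave room for uncertainty.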

Compound 4, a percentage reported as inhibition, in the whole organism at one dose (the size of the read-out at that dose, not a potency): 28.1%
For compound 4 the middle estimate is 5.9 percentage points above the measured one; the range from low to high includes it.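

In this assay, carboxy in place of hydroxymethyl gives a number 18.5 percentage points lower from compound 3 to compound 4 (beyond the scatter), so the change points the same way on the core that carries the chloro group as on the core without it, and the two steps cannot be told apart in size: the same change on two cores in this assay, a number 12.6 percentage points lower (beyond the scatter) from compound 2 to compound 1 and a number 18.5 percentage points lower (beyond the scatter) from compound 3 to compound 4, 5.9 percentage points apart, within the scatter of two such steps. Read the other way round, chloro in place of hydrogen on the carboxy core gives a number 15 percentage points lower from compound 1 to compound 4 (beyond the scatter), and this too matches its counterpart on the hydroxymethyl core: the same change on two cores in this assay, a number 9.1 percentage points lower (within the scatter) from compound 2 to compound 3 and a number 15 percentage points lower (beyond the scatter) from compound 1 to compound 4, 5.9 percentage points apart, within the scatter of two such steps. These two comparisons rest on the same four compounds, so they are one observation seen from two sides; they show that the two changes combine roughly additively here, but they do not show that this would hold on any other core, and they do not explain why either change lowers the number.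

Going by these compounds, what remains open is how other groups in place of hydroxymethyl, such as an amine or a methyl ester, or fluoro or bromo in place of chloro, would read in this assay. All four values also come from a single dose, so they give the size of the effect at that dose and leave potency open.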